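Removing the Ring Halogen from a Shared Core

The source may report more compounds than this note shows. Statements on the series, on what has been measured and on what is new or still open speak of the compounds shown alone.

Two measured compounds share one core and differ only in a halogen: compound 1 `COc1ccc(C(=O)Nc2cc(F)cc3c(=O)cc(C(=O)O)oc23)cc1` and compound 2 `COc1ccc(C(=O)Nc2cc(Cl)cc3c(=O)cc(C(=O)O)oc23)cc1`. In an assay on CHO cells for agonist activity at G protein-coupled receptor GPR35 (Rattus norvegicus), read by a beta-galactosidase reporter and beta-arrestin recruitment, with a stated time of 90 min (a lower number here means that less compound is needed, a higher number that more compound is needed for the effect), compound 1 gives 1760 nM and compound 2 gives 1830 nM, and the step of a 1.0-fold higher number from compound 1 to compound 2 (0.02 log units; within the scatter) is within the scatter. Compound 2 gives the higher of the two numbers, yet the gap to compound 1 is within the scatter. Compound 3 `COc1ccc(C(=O)Nc2cccc3c(=O)cc(C(=O)O)oc23)cc1` has not yet been measured; it differs from compound 2 by hydrogen in place of chloro on an aromatic carbon. For the measured compounds named here, the only measured step bearing on this position is a 1.0-fold higher number from compound 1 to compound 2 (0.02 log units; within the scatter), which showed that exchanging one halogen for another here changed nothing beyond the scatter. Taking the halogen away is a further change at the same place, and no step seen so far reaches beyond the scatter. Compound 3 is therefore expected to show a 1.0-fold lower number from compound 2 to compound 3 (0.01 log units; within the scatter), with an estimated 1800 nM in this assay, likely between 700 nM and 4500 nM.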

Compound 3, half-maximal effective concentration: 2160 nM
For compound 3 the middle estimate is 1.2-fold (0.08 log units) below the measured one; low and high end bracket the measured number.
By their numbers in this assay, from the lowest: compounds 1, 2 and 3 (each within the scatter of the next).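

Removing the halogen altogether gives a 1.2-fold higher number from compound 2 to compound 3 (0.07 log units; within the scatter) in this assay, and setting hydrogen against the fluoro compound gives a 1.2-fold higher number from compound 1 to compound 3 (0.09 log units; within the scatter) in the same read-out. The earlier pair showed only that one halogen could stand in for another, whereas these steps show that no halogen is needed on this aromatic carbon for the number to stay within the scatter, so fluoro, chloro and hydrogen cannot be told apart here. No measurement at hand offers an explanation for this.

The compounds shown carry only hydrogen and these two halogens at this carbon, so it remains open whether an amine, a nitrile or a longer chain there would move the number beyond the scatter. They also leave open whether changes elsewhere on the shared core, such as at the methoxy group or the carboxylic acid, would do so.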